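Shortening an aryl ether side chain in a cytotoxicity screen

The source may hold more compounds than are shown below. What is called first, only, known or untested is meant among the compounds shown, and "the series" means these compounds.

Compound 1, `CCOC(=O)CCCCCOc1cccc(CN(C(=O)c2ccc(-c3cccc(N(C)C)c3)cc2)C(C)C)c1`: in an ADME assay on HEK293 cells (Homo sapiens) for cytotoxicity, read by CellTiter-Glo and resazurin assay, with a stated time of 72 h (a lower number here means that less compound is needed, a higher number that more compound is needed for the effect), compound 1 gives > 26000 nM, which is a limit of the assay rather than a number.
Compound 2, `CCOC(=O)CCCCCOc1cccc(CN(C(=O)c2ccc(-c3cccc(OCC(C)C)c3)cc2)C(C)C)c1`: in this assay compound 2 gives > 26000 nM, likewise a limit of the assay.

Among the compounds with values here, compound 2 therefore stands only at a limit, and the one further value shown is a limit as well. Both values sit at the limit of > 26000 nM in this assay, at which 2 of the 2 values shown sit. Within the data shown here, the single measured step, a step that the two limits leave unreadable from compound 1 to compound 2, has no readable size: both of its ends are limits.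

Compound 3, `CCOC(=O)CCCCCOc1cccc(CN(C(=O)c2ccc(-c3cccc(OC(C)C)c3)cc2)C(C)C)c1`, differs from compound 2 by isopropyl in place of isobutyl on an oxygen on an aromatic ring. Among the measured compounds shown here, no measured step bears on this change, and the only step available gives no readable size, so no movement beyond the scatter is expected in this assay. For compound 3 the estimated step is a step that the limit leaves unreadable from compound 2 to compound 3. Compound 3 is expected to give about 40000 nM, within a range from 15000 nM to 120000 nM, and most likely to be reported again as a limit.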

Compound 3, half-maximal effective concentration: > 26000 nM
Compound 3 ended at the assay's limit; the forecaster's own chance of this, stated with the estimate: 85%; the middle value lies beyond the limit too.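

Compound 1, compound 2 and compound 3 all stand at one limit of the assay rather than at numbers, so no step among them can be read: the limit of > 26000 nM in this assay, at which 3 of the 3 values shown sit.

The compounds shown leave open how strongly any of the three acts in this assay, and whether swapping these side chains changes that at all.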